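Swapping the aryl amide for cyclopropyl on compound 3

The source may report more compounds than this note shows. Statements on the series, on what has been measured and on what is new or still open speak of the compounds shown alone.

The measured compounds:
Compound 1, `Nc1ccc(C(=O)Nc2nc(-c3ccccc3)nc3c2nnn3Cc2ccccc2)cc1`, 7.1 nM
Compound 2, `O=C(Nc1nc(-c2ccccc2)nc2c1nnn2Cc1ccccc1)c1cccc(F)c1`, 22 nM
Compound 3, `O=C(Nc1nc(-c2ccccc2)nc2c1nnn2Cc1ccccc1)c1ccc(C(F)(F)F)cc1`, 123 nM

All three share one core and differ only in the group on the carbonyl carbon of the amide. In an assay (strain Wistar) for displacement of a labelled ligand from adenosine receptor A1 (Rattus norvegicus), read by scintillation counting (a higher number here means a weaker inhibitor, a lower number a stronger inhibitor), compound 1 gives 7.1 nM, the lowest number of the three. Compound 2 sits higher, with a 3.1-fold higher number from compound 1 to compound 2 (0.49 log units; beyond the scatter). Compound 3 stands highest of the three numbers, with a 5.6-fold higher number from compound 2 to compound 3 (0.75 log units; beyond the scatter) and a 17-fold higher number from compound 1 to compound 3 (1.24 log units; beyond the scatter). Each of these steps is beyond the scatter, so the group on the carbonyl carbon clearly moves the number within this set.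

Compound 4, `O=C(Nc1nc(-c2ccccc2)nc2c1nnn2Cc1ccccc1)C1CC1`, has not yet been measured. The change from compound 3 is cyclopropyl in place of 4-(trifluoromethyl)phenyl on a carbonyl carbon. Within the data shown here, none of the measured steps bears directly on this change: all three exchange one substituted phenyl for another, and none replaces the aromatic ring by a small non-aromatic one. What they do show is that this position tolerates change while shifting the number over a wide span, and that compound 3 is the weakest point measured so far. Among the measured compounds shown here, with no closer precedent, the expectation is wide: compound 4 is estimated to fall somewhere between the values of compound 1 and compound 3, with an expected step of a 3.1-fold lower number from compound 3 to compound 4 (0.49 log units; beyond the scatter) in this assay. The estimate for compound 4 is 40 nM, within a range from 6 nM to 250 nM.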

Compound 4, inhibition constant: 7.5 nM
The estimate for compound 4 lay 5.3-fold (0.73 log units) above the measured number; low and high end bracket the measured number.
By their numbers in this assay, from the lowest: compounds 1 and 4 (each within the scatter of the next); then compound 2; then compound 3.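

In this assay the position proves not to need an aromatic ring: cyclopropyl, with 3 heavy atoms, in place of 4-(trifluoromethyl)phenyl gives a 16-fold lower number from compound 3 to compound 4 (1.21 log units; beyond the scatter) and a 2.9-fold lower number from compound 2 to compound 4 (0.47 log units; beyond the scatter) in this set. Against the 4-aminophenyl group the same change gives a 1.1-fold higher number from compound 1 to compound 4 (0.02 log units; within the scatter) on the carbonyl carbon, so compound 1 and compound 4 cannot be told apart, and a small non-aromatic ring reaches the same low end of the measured span as the amino-substituted phenyl ring, with far fewer heavy atoms. Nothing available gives a measured reason for these differences.

From the compounds shown here alone, whether this result belongs to cyclopropyl alone stays open, as does whether a methyl, a cyclobutyl or a longer alkyl chain on the carbonyl carbon would give a number like that of compound 4. Also open, going by these compounds, is whether a cyclohexyl ring carrying an amine would match the 4-aminophenyl group, and whether the cyclopropyl result would hold at any adenosine receptor other than this one.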